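Extending the Chain on the Ring Nitrogen

A few compounds are considered here, and "the series" means these few. Any claim that something is new, unique, unknown or untested is made for them only; others in the source may bear on it.

Compound 1 `CCN1CC(=O)N=C1NC(=O)Nc1cccc(Cl)c1` gives 250 nM in a functional assay for inhibition of metabotropic glutamate receptor 5 (Homo sapiens), read by FLIPR and calcium flux; a higher number here means a weaker inhibitor, a lower number a stronger inhibitor. Compound 2 `CCN1C(NC(=O)Nc2cccc(Cl)c2)=NC(=O)C1C` gives 410 nM in this assay, and the step of a 1.6-fold higher number from compound 1 to compound 2 (0.21 log units; within the scatter) shows the two numbers sit within the scatter of each other. Compound 3 `CCCCN1CC(=O)N=C1NC(=O)Nc1cccc(Cl)c1` differs from compound 1 by ethyl in place of hydrogen on a saturated chain carbon, two bonds along the chain from an amine nitrogen in a ring. For the measured compounds named here, the only measured step concerns a methyl on a saturated ring carbon, not this chain, so no measured step bears directly on the change. Without evidence for a shift, compound 3 is expected to show a 1.2-fold higher number from compound 1 to compound 3 (0.08 log units; within the scatter). Compound 3 is estimated at 300 nM, in a range from 120 nM to 800 nM.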

Compound 3, half-maximal inhibitory concentration: 680 nM
Beside the measured number, compound 3's estimate is 2.3-fold (0.36 log units) below it; low and high end bracket the measured number.
By their numbers in this assay, from the lowest: compounds 1, 2 and 3 (each within the scatter of the next, the first and the last beyond it).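

For the compounds shown here, the change from ethyl to butyl gives a 2.7-fold higher number from compound 1 to compound 3 (0.43 log units; beyond the scatter) in this assay and is the first step here to lie beyond the scatter, although it is modest. At this position, then, the longer chain goes with a weaker inhibitor, with one step as the only support. Nothing available explains the shift.

A single step cannot show how the number follows chain length. Propyl, a longer chain such as hexyl, or a chain ending in an amine or a carboxylic acid could each show whether the rise continues or depends on the group.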